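This account rests on a few compounds, and the source may have more. Where it says the series, first, only, none or still open, it means among the compounds named here.

Series notes. Compound 1 `O=C(Cc1ccccn1)N[C@H]1CCC[C@H](NC(=O)c2cccc(Cl)c2)C1` bears two amides on the shared core, one of them a (pyridin-2-yl)acetamide. In a functional assay on HEK293 cells for antagonist activity at metabotropic glutamate receptor 5 (Homo sapiens), read by FLIPR and calcium flux (a lower number here means a stronger inhibitor, a higher number a weaker inhibitor), compound 1 gives > 10000 nM, which is a limit of the measurement and not a number. Compound 2 `N#Cc1cccc(C(=O)N[C@H]2CCC[C@H](NC(=O)c3ccccn3)C2)c1` also sits at a limit, giving > 10000 nM in this assay. Compound 3 `O=C(N[C@H]1CCC[C@H](NC(=O)c2ccccn2)C1)c1ccccn1` gives 1150 nM in this assay. Within the data shown here, the one step between measured compounds that differ in a single place is an at least 8.6-fold lower number from compound 2 to compound 3 (0.93 log units; beyond the scatter); its true size is open because the limit of > 10000 nM in this assay, at which 2 of the 3 values shown sit, caps what can be read off.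

Compound 4 `O=C(N[C@H]1CCC[C@H](NC(=O)c2ccccc2F)C1)c1cccc(Cl)c1` differs from compound 1 by 2-fluorophenyl in place of (pyridin-2-yl)methyl on a carbonyl carbon. Among the measured compounds shown here, no measured step covers this exchange directly. The step from compound 2 to compound 3 runs toward a pyridin-2-yl group, and it was the pyridin-2-yl compound that returned a number; compound 4 moves the other way, removing a pyridin-2-yl group in favour of a carbon-only ring. Compound 1 is already at the limit. The step for compound 4 is therefore expected to be a step that the limit leaves unreadable from compound 1 to compound 4, with a limit again the likeliest outcome. The estimate for compound 4 in this assay is 15000 nM, in a range from 5000 nM to 50000 nM.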

Compound 4, half-maximal inhibitory concentration: 175 nM
Estimate against measurement, compound 4: 86-fold (1.93 log units) above, outside the stated range (below it).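

In this assay compound 1 stands at > 10000 nM, which is a limit and not a number. Among these compounds, the exchange on a carbonyl carbon whose other neighbours are an amide-type nitrogen gives an at least 57-fold lower number from compound 1 to compound 4 (1.75 log units; beyond the scatter), so this place can carry a change to a measured value, and a pyridin-2-yl group, the group gained in the only earlier readable step, is not required for a number, as compound 4 has a ring of carbon only on this carbonyl and a 3-chlorophenyl amide on the other side of the shared core and gives 175 nM. The true size of the step stays open because its starting point is capped: the limit of > 10000 nM in this assay, at which 2 of the 4 values shown sit.

The exchange alters the ring, the methylene link and the fluorine at once, so the compounds shown do not tell which of these parts carries the step. A plain phenyl, a benzyl or a 2-methoxyphenyl group on the same carbonyl carbon would separate these parts, and an amine or a carboxylic acid on that ring would test how much else this place accepts.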